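Removing One Bromo from the Lowest-Scoring Compound

The source may report more compounds than this note shows. Statements on the series, on what has been measured and on what is new or still open speak of the compounds shown alone.

Compound 1 `O=C1Nc2ccc(C(=O)c3ccco3)cc2/C1=C/c1cc(I)c(O)c(I)c1`: 26%
Compound 2 `O=C1Nc2ccc(C(=O)c3ccco3)cc2/C1=C/c1cc(Br)cc(Br)c1`: 16%
Compound 3 `COc1c(Br)cc(/C=C2\C(=O)Nc3ccc(C(=O)c4ccco4)cc32)cc1Br`: -12.6%

All three were tested in an assay on HeLa cells for inhibition of Kinesin-like protein KIF15 (Homo sapiens), read by microscopy, with stated times of 2 s and 20 s, tested at 750 nM; on this read-out lower numbers stand for less inhibition and higher numbers for more inhibition at the one concentration tested (going by the name of the read-out). Compound 3 gives the lowest number of the three, with compound 2 nearest and compound 1 furthest, both gaps beyond the scatter. Compound 4 `COc1ccc(/C=C2\C(=O)Nc3ccc(C(=O)c4ccco4)cc32)cc1Br` differs from compound 3 by hydrogen in place of bromo on an aromatic carbon. Among the compounds with values here, no measured step removes a bromo. The step that comes closest in place is a number 28.6 percentage points lower from compound 2 to compound 3 (beyond the scatter), which added a methoxy to the same ring, while the swap of the whole ring gave a number 10 percentage points lower from compound 1 to compound 2 (within the scatter). Neither step matches the change, so the direction is uncertain and a step of a number 7.6 percentage points higher from compound 3 to compound 4 (within the scatter) is expected, not clearly beyond the scatter. Compound 4 is estimated at -5%, between -30% and 20%.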

Compound 4, a percentage reported as inhibition, at one concentration (the size of the read-out at that concentration, not a potency): 2.3%
Compound 4: the middle estimate sits 7.3 percentage points below what was measured; the measured number falls inside the stated range.
By their numbers in this assay, from the lowest: compound 3; then compound 4; then compounds 2 and 1 (each within the scatter of the next).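

Within the data shown here, removing this bromo, which sits ortho to the methoxy group, is a change the earlier compounds never isolated, and it makes a measurable difference (a number 14.9 percentage points higher from compound 3 to compound 4 (beyond the scatter)). The recovery is only partial, since the ring of compound 4 still scores lower than the rings it is compared with (a number 13.7 percentage points lower from compound 2 to compound 4 (beyond the scatter); a number 23.7 percentage points lower from compound 1 to compound 4 (beyond the scatter)). Nothing available explains why the bromo has this effect. The compounds shown leave open how an amine or a carboxylic acid would score at this position. They also leave open whether removing the remaining bromo would shift the number further.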